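Cytotoxicity limit series: cyclohexyl replacing 2-fluorophenyl

The source may report more compounds than this note shows. Statements on the series, on what has been measured and on what is new or still open speak of the compounds shown alone.

Three compounds of the series share a core and carry the measured values in an ADME assay on MDBK cells (Bos taurus) for cytotoxicity; a lower number here means that less compound is tolerated, a higher number that more compound is tolerated. Compound 1, `Fc1cccc(F)c1Cn1ccc2nc(-c3c(F)cccc3F)nc-2c1`, gives a value that is a limit of the assay and not a number, > 100000 nM. Compound 2, `Fc1cccc(F)c1-c1nc2ccn(Cc3ccccc3)cc-2n1`, likewise gives only a limit, > 100000 nM. The step that the two limits leave unreadable from compound 1 to compound 2 therefore cannot be read. Compound 3, `Fc1ccccc1Cn1ccc2nc(-c3ccccc3)nc-2c1`, again returns a limit rather than a number, > 100000 nM. Compound 3 thus stands where every measured member of the series stands: the limit of > 100000 nM in this assay, at which 3 of the 3 values shown sit.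

Compound 4, `c1ccc(-c2nc3ccn(CC4CCCCC4)cc-3n2)cc1`, is not yet measured in this assay. It differs from compound 3 in one place: cyclohexyl in place of 2-fluorophenyl on a saturated chain carbon bound to an aromatic nitrogen. Going by the values given here, no measured step bears directly on an aromatic-to-saturated ring exchange at this position, and the one step that is available, a step that the two limits leave unreadable from compound 1 to compound 2, is itself unreadable. Nothing in the data points to tolerance in this assay falling off within the measured window.

Compound 4 is therefore expected to sit again at the limit, with an estimate of 100000 nM and a range from 40000 nM to 250000 nM, because compound 3 gives > 100000 nM. The expected step of a number no higher from compound 3 to compound 4 (the limit leaves the size open) is none beyond the scatter.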

Compound 4, half-maximal cytotoxic concentration: > 100000 nM
Compound 4 was reported as a limit; the forecaster's own chance of this, stated with the estimate: 80%; the middle value sits exactly at the limit.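

Compound 4 gives only a limit in this assay, as compound 3 does, so no size can be read for the step between compound 3 and compound 4: the limit of > 100000 nM in this assay, at which 4 of the 4 values shown sit.

With no value in the series a number, the compounds shown leave open how much compound is tolerated in this assay and whether cyclohexyl in place of 2-fluorophenyl changes that tolerance at all.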